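Ester tail variation on a hydroxylated naphthoquinone core

A few compounds are considered here, and "the series" means these few. Any claim that something is new, unique, unknown or untested is made for them only; others in the source may bear on it.

The compounds and their results in a functional assay on HeLa cells (Homo sapiens) for cytotoxicity, read by MTT assay; a lower number here means a stronger inhibitor, a higher number a weaker inhibitor:
compound 1, `CC(C)=CC[C@@H](OC[C@H](C)O)C1=CC(=O)c2c(O)ccc(O)c2C1=O`: 40300 nM
compound 2, `CC(=O)OCCC(=O)O[C@H](CC=C(C)C)C1=CC(=O)c2c(O)ccc(O)c2C1=O`: 17300 nM
compound 3, `CC[C@@](C)(O)CC(=O)O[C@H](CC=C(C)C)C1=CC(=O)c2c(O)ccc(O)c2C1=O`: 17900 nM

Among the three measured compounds, compound 2 gives the lowest number, though compound 3 lies within the scatter of it, as a 1.0-fold higher number from compound 2 to compound 3 (0.01 log units; within the scatter) shows; only compound 1 stands apart, with a 2.3-fold lower number from compound 1 to compound 2 (0.37 log units; beyond the scatter) and a 2.3-fold lower number from compound 1 to compound 3 (0.35 log units; beyond the scatter) both beyond the scatter.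

Compound 4, `CCCC(C)(O)CC(=O)O[C@H](CC=C(C)C)C1=CC(=O)c2c(O)ccc(O)c2C1=O`, has not yet been measured. Its difference from compound 2 is 1-hydroxy-1-methylbutyl in place of acetoxymethyl on a saturated chain carbon bound to a carbonyl carbon The step that bears most directly on it is a 1.0-fold higher number from compound 2 to compound 3 (0.01 log units; within the scatter), where the same acetoxymethyl group was replaced by the one-carbon-shorter 1-hydroxy-1-methylpropyl without any change beyond the scatter. Within the data shown here, nothing among the measured compounds suggests that lengthening this chain by one carbon would move the number further, so no step beyond the scatter is expected in either direction: a 1.0-fold higher number from compound 2 to compound 4 (0.00 log units; within the scatter). Compound 4 is therefore estimated at 17500 nM, between 9000 nM and 35000 nM.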

Compound 4, half-maximal inhibitory concentration: 72000 nM
Compound 4: the middle estimate sits 4.1-fold (0.61 log units) below what was measured, and the stated range ends below it.
By their numbers in this assay, from the lowest: compounds 2 and 3 (each within the scatter of the next); then compounds 1 and 4 (each within the scatter of the next).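

In this assay, the place on a saturated chain carbon bound to a carbonyl carbon proves sensitive to the exact tail, which the match between compounds 2 and 3 had not revealed: the change from acetoxymethyl to 1-hydroxy-1-methylbutyl gives a 4.2-fold higher number from compound 2 to compound 4 (0.62 log units; beyond the scatter) and the change from 1-hydroxy-1-methylpropyl to 1-hydroxy-1-methylbutyl gives a 4.0-fold higher number from compound 3 to compound 4 (0.60 log units; beyond the scatter). Compound 4 also no longer stands apart from compound 1, as a 1.8-fold higher number from compound 1 to compound 4 (0.25 log units; within the scatter) shows, so an ester tail at this place does not by itself keep the lower number seen with compounds 2 and 3. No evidence available here accounts for this result.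

On these data alone, it remains open whether a longer chain, such as 1-hydroxy-1-methylpentyl, would raise the number further. As far as these compounds go, it is also open whether 1-amino-1-methylbutyl, with an amine in place of the hydroxyl, would behave like 1-hydroxy-1-methylbutyl.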